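The compounds below may be only part of what the source reports. "The series", "measured", "known", "first", "only" and "open" are said of these compounds alone.

Measured in a functional assay on A2780 cells (Homo sapiens) for antiproliferative activity, read by sulforhodamine B assay, with a stated time of 48 h; a higher number here means a weaker inhibitor of growth, a lower number a stronger inhibitor of growth:
- compound 1 `CC(C)(C)[Si](C)(C)O[C@@H]1CCCO[C@@H]1COCC(=O)O`: > 100000 nM, a limit
- compound 2 `O=C1COC[C@H]2OCCC[C@@H]2O1`: > 100000 nM, a limit

Compound 1 has no numerical value and stands only at a limit. The same holds across the small set: the limit of > 100000 nM in this assay, at which 2 of the 2 values shown sit. For the measured compounds named here, with no measured number in the set, no step is available to size a structural change.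

Compound 3 `CC(C)(C)[Si](C)(C)O[C@@H]1CCCO[C@@H]1COCCCO` differs from compound 1 at one place: 2-hydroxyethyl in place of carboxy on a saturated chain carbon bound to an oxygen on a saturated carbon. This puts 2-hydroxyethyl in place of carboxy on a saturated chain carbon bound to an oxygen on a saturated carbon. The same difference, cut one bond further out, reads carboxymethyl to 3-hydroxypropyl.

The expectation rests on compound 1, whose > 100000 nM is a limit. No change beyond the scatter is expected in this assay, although any shift would be expected toward stronger inhibition of growth. The expected step, an at least 1.2-fold lower number from compound 1 to compound 3 (0.09 log units; that floor lies within the scatter), is read against that limit, and another report of a limit is the likelier outcome. For compound 3 the estimated value is 80000 nM, with an expected range of 30000 nM to 150000 nM.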

Compound 3, concentration for 50% growth inhibition: > 100000 nM
Compound 3: only a limit was reported (the forecaster's own chance of this, stated with the estimate: 70%); at least 1.2-fold (0.09 log units) between middle value and limit.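

No step can be read from compound 1 to compound 3, since compound 3 gives > 100000 nM, a limit, and compound 1 also stands only at a limit. All values in the set sit at one limit: the limit of > 100000 nM in this assay, at which 3 of the 3 values shown sit.

The compounds shown leave open whether any change to the shared core gives a measurable value in this assay.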